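Retinoid amides: from compound 1 to compound 4

The source may report more compounds than this note shows. Statements on the series, on what has been measured and on what is new or still open speak of the compounds shown alone.

Measured so far in a functional assay on MDA-MB-468 cells (Homo sapiens) for inhibition, read by MTT assay; a higher number here means a weaker inhibitor of growth, a lower number a stronger inhibitor of growth
- compound 1 `CC1=C(/C=C/C(C)=C/C=C/C(C)=C\C(=O)Nc2ccccc2)C(C)(C)CCC1n1ccnc1` gives 2540 nM
- compound 2 `CC1=C(/C=C/C(C)=C/C=C/C(C)=C\C(=O)Nc2cccc(F)c2)C(C)(C)CCC1n1ccnc1` gives 6760 nM
- compound 3 `CC1=C(/C=C/C(C)=C/C=C/C(C)=C\C(=O)Nc2ccccc2)C(C)(C)CC=C1c1cncnc1` gives 22900 nM

Compound 1 has the lowest number of the three. Compound 4 `CC1=C(/C=C/C(C)=C/C=C/C(C)=C\C(=O)NCc2ccc(O)cc2)C(C)(C)CCC1n1ccnc1` is unmeasured and carries 4-hydroxybenzyl in place of phenyl on an amide-type nitrogen. Among the measured compounds shown here, one measured step bears on this, a change to the same phenyl group (a 2.7-fold higher number from compound 1 to compound 2 (0.43 log units; beyond the scatter)). It is a smaller edit, so it gives only a rough scale. A modest step in this assay is expected, with no firm direction. The estimated step is small (a 1.3-fold lower number from compound 1 to compound 4 (0.10 log units; within the scatter)). Compound 4 is expected at about 2000 nM and is estimated to fall between 500 nM and 8000 nM in that assay.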

Compound 4, concentration for 50% growth inhibition: 2700 nM
Beside the measured number, compound 4's estimate is 1.4-fold (0.13 log units) below it; the measured number falls inside the stated range.
By their numbers in this assay, from the lowest: compounds 1 and 4 (each within the scatter of the next); then compound 2; then compound 3.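

Moving the aromatic ring off the amide-type nitrogen and adding a hydroxyl leaves the reading in this assay unchanged within the scatter, with a 1.1-fold higher number from compound 1 to compound 4 (0.03 log units; within the scatter). So this position accepts 4-hydroxybenzyl as well as phenyl, and 4-hydroxybenzyl also compares favourably with 3-fluorophenyl, with a 2.5-fold lower number from compound 2 to compound 4 (0.40 log units; beyond the scatter). No supporting evidence accounts for these readings at this position.

Plain benzyl or phenethyl on that nitrogen would be needed to separate any contribution of the hydroxyl from that of the added carbon. From the compounds shown here alone, how 4-hydroxybenzyl reads on the core of compound 3 also remains open.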